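The source may report more compounds than this note shows. Statements on the series, on what has been measured and on what is new or still open speak of the compounds shown alone.

Compound 3 `O=C1COc2ccc(-c3cnc(Cl)c(NS(=O)(=O)c4ccc(F)cc4)c3)cc2N1` is reported in a functional assay on A549 cells (Homo sapiens) for antiproliferative activity, read by MTT assay, with a stated time of 72 h (on this read-out lower numbers stand for stronger inhibition and higher numbers for weaker inhibition), only as > 40000 nM, which is the limit of > 40000 nM in this assay, at which 1 of the 3 values shown sits, rather than a number. Compound 1 `O=C1COc2ccc(-c3cnc(Cl)c(NS(=O)(=O)c4ccc(F)cc4)c3)cc2N1c1ccc(Cl)cc1` gives 21600 nM in this assay, and compound 2 `Cc1ccc(N2C(=O)COc3ccc(-c4cnc(Cl)c(NS(=O)(=O)c5ccc(F)cc5)c4)cc32)cc1` gives 30900 nM. Compound 4 `COc1ccc(N2C(=O)COc3ccc(-c4cnc(Cl)c(NS(=O)(=O)c5ccc(F)cc5)c4)cc32)cc1` differs from compound 3 by 4-methoxyphenyl in place of hydrogen on an amide-type nitrogen in a ring. Going by the values given here, two measured steps bear on this change: the step of an at least 1.8-fold higher number from compound 1 to compound 3 (0.26 log units; that floor lies within the scatter) and the step of an at least 1.2-fold higher number from compound 2 to compound 3 (0.11 log units; that floor lies within the scatter). Both run the opposite way, from an aryl group on that nitrogen to hydrogen, and both are small. Turning them around, compound 4 is expected to show a step of an at least 1.4-fold lower number from compound 3 to compound 4 (0.15 log units; that floor lies within the scatter) toward a lower number, but not beyond the scatter. Compound 4 is therefore estimated at 28000 nM in this assay, with a range from 12000 nM to 65000 nM.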

Compound 4, half-maximal inhibitory concentration: 30400 nM
Estimate against measurement, compound 4: 1.1-fold (0.04 log units) below, and the stated range covers the measured number.
By their numbers in this assay, from the lowest: compounds 1, 4 and 2 (each within the scatter of the next). At a limit, above all of these: compound 3.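

In this assay, methoxy in place of methyl gives a 1.0-fold lower number from compound 2 to compound 4 (0.01 log units; within the scatter) and methoxy in place of chloro gives a 1.4-fold higher number from compound 1 to compound 4 (0.15 log units; within the scatter) so all three aryl groups on this nitrogen sit within the scatter of one another. On these data alone, putting 4-methoxyphenyl in place of hydrogen gives an at least 1.3-fold lower number from compound 3 to compound 4 (0.11 log units; that floor lies within the scatter) and the true size of that step stays unknown. Compound 3 is reported only as a limit: the limit of > 40000 nM in this assay, at which 1 of the 4 values shown sits.

As far as these compounds go, whether an amine or a carboxylic acid on that phenyl ring would move the number beyond the scatter stays open. So does the effect of a longer chain on this nitrogen.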